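Cytotoxicity notes: ethyl in place of 2-methylphenyl

The source may hold more compounds than are shown below. What is called first, only, known or untested is meant among the compounds shown, and "the series" means these compounds.

Cytotoxicity in an ADME assay on RD cells (Homo sapiens) for cytotoxicity (on this read-out higher numbers stand for lower toxicity in this test and lower numbers for higher toxicity in this test), has so far been recorded for three members of the series. Compound 1 `O=C1Nc2ccccc2/C1=N/NC(=S)N1CCCCC1` reaches only a limit of this assay, > 25000 nM. Compound 2 `O=C1Nc2ccccc2/C1=N/NC(=S)Nc1ccc(F)cc1` likewise gives only a limit, > 25000 nM. Compound 3 `Cc1ccccc1NC(=S)N/N=C1\C(=O)Nc2ccccc21`, the starting point of the step followed here, also stands at a limit, > 25000 nM. Going by the values given here, all three values therefore sit at the same limit, (the limit of > 25000 nM in this assay, at which 3 of the 3 values shown sit), and the single one-point change measured so far, a step that the two limits leave unreadable from compound 2 to compound 3, is of unreadable size.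

Compound 4 `CCNC(=S)N/N=C1\C(=O)Nc2ccccc21` has not yet been measured in this assay. It differs from compound 3 in one place: ethyl in place of 2-methylphenyl on an amide-type nitrogen. Among the compounds with values here, the only measured step touching the amide-type nitrogen is a step that the two limits leave unreadable from compound 2 to compound 3, whose size cannot be read, so no direction beyond the scatter can be derived from it. Compound 4 is accordingly expected to stand at the limit as well, with an estimate of 30000 nM (range 10000 nM to 100000 nM). The step this expectation implies, a step that the limit leaves unreadable from compound 3 to compound 4, is expected to be none beyond the scatter.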

Compound 4, half-maximal cytotoxic concentration: > 25000 nM
Compound 4: no number, only a limit; the forecaster's own chance of this, stated with the estimate: 85%; the middle value does not contradict the limit.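

The steps to compound 4 from compound 1, compound 2 and compound 3 cannot be read, as all four compounds stand at a single limit: the limit of > 25000 nM in this assay, at which 4 of the 4 values shown sit. The compounds shown leave open whether piperidin-1-yl, 4-fluorophenyl, 2-methylphenyl and ethyl differ at all in this assay and at what concentration any of these compounds becomes cytotoxic.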